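Swapping a Nitrophenyl for a Methylphenyl on a Weak Core

The source may report more compounds than this note shows. Statements on the series, on what has been measured and on what is new or still open speak of the compounds shown alone.

Compound 2 `N#Cc1c(Nc2cccc([N+](=O)[O-])c2)nc(SCc2cn(Cc3ccccc3Cl)nn2)nc1-c1ccccc1` carries a 3-nitrophenyl on a nitrogen of the shared core. In a functional assay on MCF7 cells (Homo sapiens) for inhibition, read by MTT assay, with a stated time of 72 h (on this read-out higher numbers stand for weaker inhibition and lower numbers for stronger inhibition), compound 2 reaches only the limit of the assay, > 64000 nM. Compound 3 `Cc1ccc(Cn2cc(CSc3nc(Nc4ccccc4F)c(C#N)c(-c4ccccc4)n3)nn2)cc1` also stops at the limit in this assay, at > 64000 nM. Compound 1 `C#CCSc1nc(Nc2ccc(OC)cc2)c(C#N)c(-c2ccccc2)n1`, with a different thioether and a methoxyphenyl, gives 35600 nM in this assay. Compound 4 `Cc1ccc(Nc2nc(SCc3cn(Cc4ccccc4Cl)nn3)nc(-c3ccccc3)c2C#N)cc1` differs from compound 2 by 4-methylphenyl in place of 3-nitrophenyl on a nitrogen on an aromatic ring. Given (the limit of > 64000 nM in this assay, at which 2 of the 3 values shown sit), no measured step exists to lean on, so the change is expected to shift the number, if at all, by no more than the scatter. Compound 4 is expected to give about 55000 nM in this assay, within 20000 nM to 150000 nM. The step of an at least 1.1-fold lower number from compound 2 to compound 4 (0.06 log units; that floor lies within the scatter) is expected to stay within scatter.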

Compound 4, half-maximal inhibitory concentration: 9420 nM
The estimate for compound 4 lay 5.8-fold (0.77 log units) above the measured number, and the stated range ends above it.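

In this assay, the group on this nitrogen clearly matters: 4-methylphenyl in place of 3-nitrophenyl brings an at least 6.7-fold lower number from compound 2 to compound 4 (0.83 log units; beyond the scatter). The thioether shared by compound 2 and compound 4 therefore does not by itself hold a compound at the limit. The step is only a minimum because the value of compound 2 is a limit: the limit of > 64000 nM in this assay, at which 2 of the 4 values shown sit.

The compounds shown do not separate the effect of adding the methyl group from that of removing the nitro group or moving the substituent on the ring. An unsubstituted phenyl or a 3-methylphenyl on this nitrogen would help to tell these apart.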